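From 4-cyanophenyl to 2-chlorophenyl on a saturated chain

The source may report more compounds than this note shows. Statements on the series, on what has been measured and on what is new or still open speak of the compounds shown alone.

Two chain amides have been measured in a functional assay on PANC-1 cells (Homo sapiens) for cytotoxicity, read by WST assay, with a stated time of 24 h; a lower number here means a stronger inhibitor, a higher number a weaker inhibitor. Compound 1 (`O=C(/C=C/CCCCCCc1ccccc1)N1CCCC1`) gives > 100000 nM, which is a limit of the assay and not a number. Compound 2 (`N#Cc1ccc(CCCCCCCCC(=O)N2CCCCC2)cc1`) gives > 100000 nM, also a limit and not a number. Among the measured compounds shown here, the evidence so far is therefore (the limit of > 100000 nM in this assay, at which 2 of the 2 values shown sit), and no measured step is available.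

Compound 3 (`O=C(CCCCCCCCc1ccccc1Cl)N1CCCCC1`) carries 2-chlorophenyl in place of 4-cyanophenyl on a saturated chain carbon, eight bonds along the chain from a carbonyl carbon.

Resting on compound 2 and its limit of > 100000 nM, no step beyond the scatter is expected in this assay, and a further limit is the likeliest report. The expected change, a number no higher from compound 2 to compound 3 (the limit leaves the size open), is only an estimate. For compound 3 the estimated half-maximal inhibitory concentration is 100000 nM, within an expected range of 30000 nM to 300000 nM.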

Compound 3, half-maximal inhibitory concentration: > 100000 nM
Compound 3: a limit, no number (the forecaster's own chance of this, stated with the estimate: 75%); the middle value lies on the limit itself.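

In this assay compound 3 gives > 100000 nM, a limit of the assay and not a number. Compound 2 also stands at a limit, so no step can be read between compound 2 and compound 3. The compounds shown leave open whether any such chain amide gives a readable number: the limit of > 100000 nM in this assay, at which 3 of the 3 values shown sit.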